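Methoxy in place of ethyl: working notes

This account rests on a few compounds, and the source may have more. Where it says the series, first, only, none or still open, it means among the compounds named here.

In a physicochemical assay for solubility, in the presence of a further agent that is not named here (on this read-out higher numbers stand for higher solubility and lower numbers for lower solubility), compound 1 `CCc1ccc2c(c1)[n+]([O-])c(NCCN(C)C)n[n+]2[O-]` gives > 49000000 nM, which is a limit of the assay. Among the compounds with values here, compound 2 `CCc1ccc2c(c1)[n+]([O-])c(NCCN1CCCCC1)n[n+]2[O-]` gives 39000000 nM, the only actual number so far. Compound 3 `COc1ccc2c(c1)[n+]([O-])c(NCCN1CCCCC1)n[n+]2[O-]` differs from it as methoxy in place of ethyl on an aromatic carbon. Within the data shown here, the single measured step, an at least 1.2-fold lower number from compound 1 to compound 2 (0.09 log units; that floor lies within the scatter), changes the chain rather than this aromatic carbon, so it bears only indirectly and offers no measured precedent for a larger shift. The expected step is a 1.1-fold lower number from compound 2 to compound 3 (0.05 log units; within the scatter), with none expected beyond the scatter in this assay. For compound 3 the estimate is 35000000 nM, with an expected range of 15000000 nM to 70000000 nM.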

Compound 3, solubility: 45000000 nM
The estimate for compound 3 lay 1.3-fold (0.11 log units) below the measured number; measured number inside the range.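

In this assay, methoxy in place of ethyl on this aromatic carbon gives a 1.2-fold higher number from compound 2 to compound 3 (0.06 log units; within the scatter). Within the data shown here, this is the first measured change at this aromatic carbon, as the earlier pair differs only in the chain. With the piperidin-1-yl chain held constant, the exchange of ethyl for methoxy, which adds one hydrogen-bond acceptor by count, gives no step beyond the scatter.

As far as these compounds go, whether an amine or a carboxylic acid on this aromatic carbon would give a step beyond the scatter remains open. The same question cannot be put numerically to the dimethylamino chain, as compound 1 gives only a limit: the limit of > 49000000 nM in this assay, at which 1 of the 3 values shown sits.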